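Moving the Carboxylic Acid on a Shared Lactam Core

A few compounds are considered here, and "the series" means these few. Any claim that something is new, unique, unknown or untested is made for them only; others in the source may bear on it.

Two compounds of the shared core have numbers in an assay on HEK293 cells for positive allosteric modulation of metabotropic glutamate receptor 2 (Rattus norvegicus), read by thallium flux; a lower number here means that less compound is needed, a higher number that more compound is needed for the effect. Compound 1 `O=C(O)c1ccc(-c2cccc(COc3ccc4c(c3)CN(C3CCCC3)C4=O)c2)c(Cl)c1` gives 110 nM and stands highest of the two. Compound 2 `O=C(O)c1cc(-c2cccc(-c3ccc4c(c3)CN(C3CCCC3)C4=O)c2)ccc1Cl` gives 20 nM, a lower number that lies beyond the scatter, though it differs from compound 1 in more than one place. Compound 3 `O=C(O)c1ccc(Cl)c(-c2cccc(COc3ccc4c(c3)CN(C3CCCC3)C4=O)c2)c1` is not yet measured; it differs from compound 1 only in the change (5-carboxy-2-chlorophenyl in place of 4-carboxy-2-chlorophenyl on an aromatic carbon). With no single-place comparison in hand, a small step toward a higher number is expected, a 1.8-fold higher number from compound 1 to compound 3 (0.26 log units; within the scatter). Compound 3 is estimated at 200 nM, within 60 nM to 700 nM.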

Compound 3, half-maximal effective concentration: 90 nM
For compound 3 the middle estimate is 2.2-fold (0.35 log units) above the measured one; the range from low to high includes it.
By their numbers in this assay, from the lowest: compound 2; then compounds 3 and 1 (each within the scatter of the next).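

In this assay, the step with 5-carboxy-2-chlorophenyl in place of 4-carboxy-2-chlorophenyl is a 1.2-fold lower number from compound 1 to compound 3 (0.09 log units; within the scatter). On this aromatic carbon, meta to a large group, the two arrangements of the same atoms therefore cannot be told apart. Nothing measured here bears on the reason for this result. On these data alone, it remains open what a tetrazole or a primary amide would do in place of the carboxylic acid, or a methyl group in place of the chlorine. Compound 2 has no single-place partner among these compounds, so what lies behind its number cannot be read.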